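The source may report more compounds than this note shows. Statements on the series, on what has been measured and on what is new or still open speak of the compounds shown alone.

Three compounds have been measured in an ADME assay on HEK-293T cells (Homo sapiens) for cytotoxicity, read by MTT assay, with a stated time of 48 h; a higher number here means that more compound is tolerated, a lower number that less compound is tolerated:
compound 1 `CC1(C)[C@H]2CC[C@]1(C)[C@H](OC(=O)CN1CCCCC1)C2` gives 141000 nM
compound 2 `CC1CCN(CC(=O)O[C@@H]2C[C@@H]3CC[C@@]2(C)C3(C)C)CC1` gives 71600 nM
compound 3 `CN1CCN(CCCC(=O)O[C@@H]2C[C@@H]3CC[C@@]2(C)C3(C)C)CC1` gives 99200 nM

Compound 2 shows the smallest of the three numbers, yet compound 3 and compound 1 both fall within the usual scatter of it, so no real difference between them can be read. For the measured compounds named here, the only step measured between close neighbours, a 2.0-fold lower number from compound 1 to compound 2 (0.29 log units; within the scatter), was itself within the scatter. Compound 4 `CN(C)CC(=O)O[C@@H]1C[C@@H]2CC[C@@]1(C)C2(C)C` has not yet been measured; it differs from compound 2 by dimethylamino in place of 4-methylpiperidin-1-yl on a saturated chain carbon bound to a carbonyl carbon. Going by the values given here, no measured step replaces 4-methylpiperidin-1-yl with dimethylamino, so the data give no direct guide for this change, and the one step that is known was flat. Compound 4 is therefore expected to give a number within the scatter of compound 2, a step of a 1.3-fold higher number from compound 2 to compound 4 (0.10 log units; within the scatter), with an estimated 90000 nM and a range from 45000 nM to 180000 nM.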

Compound 4, half-maximal cytotoxic concentration: 389000 nM
Estimate against measurement, compound 4: 4.3-fold (0.64 log units) below; the measured number lies above the stated range.
By their numbers in this assay, from the lowest: compounds 2, 3 and 1 (each within the scatter of the next); then compound 4.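

In this assay, the group on this saturated chain carbon bound to a carbonyl carbon does change the number: dimethylamino in place of 4-methylpiperidin-1-yl gives a 5.4-fold higher number from compound 2 to compound 4 (0.74 log units; beyond the scatter) and dimethylamino in place of piperidin-1-yl gives a 2.8-fold higher number from compound 1 to compound 4 (0.44 log units; beyond the scatter). Both steps lie beyond the scatter, unlike the earlier methyl step on the ring. Nothing shown explains why this number rises.

Still open, on these data alone, is whether the ring or simply the size of the group matters. Dipropylamino, an open-chain amine with more carbons, on the same carbon could help separate the two.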